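Swapping a sulfonamide for an oxadiazole on the pyridine

The source may hold more compounds than are shown below. What is called first, only, known or untested is meant among the compounds shown, and "the series" means these compounds.

Compound 1 `CC(C)(C)c1ccc(NC(=O)c2ccc(-c3ncccc3C#N)cc2)cc1`: 13 nM
Compound 2 `CC(C)(C)c1ccc(NC(=O)c2ccc(-c3ncccc3NS(C)(=O)=O)cc2)cc1`: 35 nM
Compound 3 `CCS(=O)(=O)Nc1cccnc1-c1ccc(C(=O)Nc2ccc(C(C)(C)C)cc2)cc1`: 4 nM

In a functional assay for antagonist activity at transient receptor potential cation channel subfamily V member 1 (Rattus norvegicus) (on this read-out lower numbers stand for stronger inhibition and higher numbers for weaker inhibition), compound 3 gives the lowest of the three numbers, with compound 1 the nearest and compound 2 the furthest. The step to compound 4 `CC(C)(C)c1ccc(NC(=O)c2ccc(-c3ncccc3-c3nnco3)cc2)cc1` is 1,3,4-oxadiazol-2-yl in place of (ethylsulfonyl)amino on an aromatic carbon. Within the data shown here, no measured step changes this position to an aromatic ring, so none bears on it directly. The steps that do touch this position are a 2.7-fold higher number from compound 1 to compound 2 (0.43 log units; beyond the scatter), a 3.3-fold lower number from compound 1 to compound 3 (0.51 log units; beyond the scatter) and an 8.8-fold lower number from compound 2 to compound 3 (0.94 log units; beyond the scatter): all modest, but together they span the whole range from compound 2 to compound 3. Among the measured compounds shown here, compound 4 loses the single hydrogen-bond donor of compound 3 and gains a ring, a change of a kind not yet tested here, so the outcome is uncertain. A somewhat higher number is expected for compound 4, of the order of the step of a 3.8-fold higher number from compound 3 to compound 4 (0.57 log units; beyond the scatter). The estimate for compound 4 in this assay is 15 nM, with a range from 4 nM to 60 nM.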

Compound 4, half-maximal inhibitory concentration: 59 nM
Compound 4: the middle estimate sits 3.9-fold (0.59 log units) below what was measured; the measured number falls inside the stated range.
By their numbers in this assay, from the lowest: compound 3; then compound 1; then compounds 2 and 4 (each within the scatter of the next).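

In this assay, among these compounds, the change gives a 15-fold higher number from compound 3 to compound 4 (1.17 log units; beyond the scatter), the only step at this position printed as large, so replacing (ethylsulfonyl)amino with a five-membered aromatic ring can cost more than any change among the earlier compounds. Set against the shorter sulfonamide, the same ring gives a 1.7-fold higher number from compound 2 to compound 4 (0.23 log units; within the scatter), which leaves those two groups indistinguishable, while against the nitrile it gives a 4.5-fold higher number from compound 1 to compound 4 (0.66 log units; beyond the scatter). The compounds shown offer no independent data that could explain these differences.

From the compounds shown here alone, whether the result belongs to the 1,3,4-oxadiazol-2-yl ring in particular or would extend to a tetrazole or a pyrazole remains open. So does whether a propyl chain on the sulfonyl group, or a simple amine at this position, would follow compound 3 or compound 4.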